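Isobutoxy in place of butoxy on the ethyl ester

A few compounds are considered here, and "the series" means these few. Any claim that something is new, unique, unknown or untested is made for them only; others in the source may bear on it.

Compound 1 `CCCCOc1ccccc1-c1ncc(C(=O)O)c(=O)[nH]1` gives 0.5 mg/kg in a functional assay on the whole organism (strain Sprague-Dawley) for inhibition, with Rattus norvegicus as the target, with a stated time of 10 min; a higher number here means that more compound is needed for the effect, a lower number that less compound is needed. Compound 2 `CC(C)COc1ccccc1-c1ncc(C(=O)O)c(=O)[nH]1` differs from it by isopropyl in place of propyl on a saturated chain carbon bound to an oxygen on an aromatic ring; in this assay compound 2 gives 0.5 mg/kg, the step being no change at the digits printed from compound 1 to compound 2 (within the scatter). Compound 3 `CCCCOc1ccccc1-c1ncc(C(=O)OCC)c(=O)[nH]1` is built on a different core, the difference between the two cores being (ethyl in place of hydrogen on an oxygen next to a carbonyl group); in this assay compound 3 gives 0.5 mg/kg, with no change at the digits printed from compound 1 to compound 3 (within the scatter). All three measured values thus sit within the scatter of one another, so no order among them can be read.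

Compound 4 `CCOC(=O)c1cnc(-c2ccccc2OCC(C)C)[nH]c1=O` has not yet been measured in this assay. For the measured compounds named here, it differs from compound 3 by isopropyl in place of propyl on a saturated chain carbon bound to an oxygen on an aromatic ring, which is the same change, in the same place word for word, as the one from compound 1 to compound 2. Since that earlier change left the read-out unmoved on the acid core, and the ester core of compound 3 also sits level with both acids, the step is expected to be no change at the digits printed from compound 3 to compound 4 (within the scatter), flat like no change at the digits printed from compound 1 to compound 2 (within the scatter). Compound 4 is accordingly estimated at 0.5 mg/kg, with a likely range from 0.25 mg/kg to 1 mg/kg.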

Compound 4, dose for 50% inhibition: 3 mg/kg
Compound 4: the middle estimate sits 6.0-fold (0.78 log units) below what was measured; measured number above the stated range.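

In this assay, the change from butoxy to isobutoxy does not carry from the acid to the ethyl ester. On the ester it gives a 6.0-fold higher number from compound 3 to compound 4 (0.78 log units; beyond the scatter), and beside the step on the acid it reads: the same change on two cores in this assay, no change at the digits printed (within the scatter) from compound 1 to compound 2 and a 6.0-fold higher number (0.78 log units; beyond the scatter) from compound 3 to compound 4, 6.0-fold (0.78 log units) apart, beyond the scatter of two such steps

Read the other way, ethyl in place of hydrogen on an oxygen next to a carbonyl group gives a 6.0-fold higher number from compound 2 to compound 4 (0.78 log units; beyond the scatter), and beside the same change with butoxy in place it reads: the same change on two cores in this assay, no change at the digits printed (within the scatter) from compound 1 to compound 3 and a 6.0-fold higher number (0.78 log units; beyond the scatter) from compound 2 to compound 4, 6.0-fold (0.78 log units) apart, beyond the scatter of two such steps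

For the compounds shown here, both comparisons rest on the same four compounds and on the single value of compound 4, so they show that the two changes do not act independently here, but they establish no general rule for the series and give no reason for the shift.

Going by these compounds, whether the shift belongs to chain branching in general or only to isobutoxy on the ethyl ester stays open. On these data alone, it is equally open whether a longer chain such as hexyloxy, or a primary amide in place of the ester, would follow the acid pair or the ester pair.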